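The compounds below may be only part of what the source reports. "The series", "measured", "known", "first", "only" and "open" are said of these compounds alone.

Measured in a functional assay on CCRF-CEM cells (Homo sapiens) for antiproliferative activity; a higher number here means a weaker inhibitor of growth, a lower number a stronger inhibitor of growth:
compound 1 `COCCCCCCCCCCC/C=C1\CC(CO)(COC(=O)C(C)(C)C)OC1=O`: 0.701 ug/mL
compound 2 `COC(=O)CCCCCCCCCCCCCC/C=C1\CC(CO)(COC(=O)C(C)(C)C)OC1=O`: 0.691 ug/mL
compound 3 `CCCCCCCCC(O)CCCCCC/C=C1\CC(CO)(COC(=O)C(C)(C)C)OC1=O`: 5.72 ug/mL

Compound 3, at 5.72 ug/mL, has the highest number of the three, and its gaps to compound 1 and compound 2 both lie beyond the scatter.

Next is compound 4 `CC(C)(C)C(=O)OCC1(CO)C/C(=C\CCCCCCCCCCCO)C(=O)O1`, with 5-hydroxypentyl in place of 1-hydroxynonyl on a saturated chain carbon, six bonds along the chain from a double-bonded chain carbon.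

The closest evidence is an 8.2-fold higher number from compound 1 to compound 3 (0.91 log units; beyond the scatter), where 1-hydroxynonyl replaced 5-methoxypentyl at that same place. For the measured compounds named here, compound 4 removes 1-hydroxynonyl again, but it carries 5-hydroxypentyl rather than 5-methoxypentyl, and no measured compound isolates that difference. The other measured step, a 1.0-fold lower number from compound 1 to compound 2 (0.01 log units; within the scatter), lies within the scatter and concerns a different place on the chain, so it bears only weakly.

A move to a lower number in this assay is therefore expected, probably not quite reaching the level of compound 1 at 0.701 ug/mL. The expected step is a 4.8-fold lower number from compound 3 to compound 4 (0.68 log units; beyond the scatter). The estimate for compound 4 is 1.2 ug/mL, with an expected range of 0.4 ug/mL to 3.5 ug/mL.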

Compound 4, concentration for 50% growth inhibition: 0.65 ug/mL
Beside the measured number, compound 4's estimate is 1.8-fold (0.27 log units) above it; low and high end bracket the measured number.
By their numbers in this assay, from the lowest: compounds 4, 2 and 1 (each within the scatter of the next); then compound 3.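

In this assay the step of an 8.8-fold lower number from compound 3 to compound 4 (0.94 log units; beyond the scatter) is beyond the scatter, although 1-hydroxynonyl and 5-hydroxypentyl count the same hydrogen-bond donors and acceptors, so the presence of a hydroxy group alone does not set the number at this place on a saturated chain carbon. Hydrogen in place of methyl on an oxygen on a saturated carbon gives a 1.1-fold lower number from compound 1 to compound 4 (0.03 log units; within the scatter) and hydroxy in place of 3-(methoxycarbonyl)propyl gives a 1.1-fold lower number from compound 2 to compound 4 (0.03 log units; within the scatter) so the hydroxy, methoxy and methyl ester forms of the chain are not separated in this assay. No supporting measurement accounts for the high number of compound 3.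

Compound 3 and compound 4 differ in both the size of the group and where its hydroxy stands, and these two changes remain unresolved. On these data alone, how an amine or a carboxylic acid in place of the hydroxy of compound 4 would read also remains open.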